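The source may report more compounds than this note shows. Statements on the series, on what has been measured and on what is new or still open speak of the compounds shown alone.

Compound 3 `Cc1noc(-c2nc(C)c3c(c2N)C(=O)N(Cc2cccc(C(F)(F)F)c2)C3=O)n1` carries 3-(trifluoromethyl)phenyl on the saturated chain carbon bound to an amide-type nitrogen in a ring. In a physicochemical assay for solubility, using the shake flask method, in simulated intestinal fluid, measured as kinetic solubility, with a stated time of 2 h, at 25 degrees C, at pH 6.5 (on this read-out higher numbers stand for higher solubility and lower numbers for lower solubility), compound 3 gives only a limit, < 5000 nM. Compound 1 `CCCOC(=O)c1nc(C)c2c(c1N)C(=O)N(Cc1ccccc1)C2=O` also gives a limit, < 5000 nM. Compound 2 `Cc1nnc(-c2nc(C)c3c(c2N)C(=O)N(Cc2ccccc2)C3=O)o1` likewise sits at a limit, < 5000 nM. Going by the values given here, the one step with two readings, a step that the two limits leave unreadable from compound 1 to compound 2, is thus of unreadable size, and the limit of < 5000 nM in this assay, at which 3 of the 3 values shown sit, is all the series shows. Compound 4 `Cc1noc(-c2nc(C)c3c(c2N)C(=O)N(Cc2ccc(N(C)C)cc2)C3=O)n1` differs from compound 3 by 4-(dimethylamino)phenyl in place of 3-(trifluoromethyl)phenyl on a saturated chain carbon bound to an amide-type nitrogen in a ring. Among the compounds with values here, no measured step touches either of these groups, so no direction can be read from the numbers. The value of compound 4 is estimated at 4000 nM, range 500 nM to 30000 nM, an expected step that the limit leaves unreadable from compound 3 to compound 4, with a fair chance that this assay again reports only a limit.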

Compound 4, solubility: 7400 nM
Beside the measured number, compound 4's estimate is 1.9-fold (0.27 log units) below it, within the range that was stated.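

At this position, on a saturated chain carbon bound to an amide-type nitrogen in a ring, 4-(dimethylamino)phenyl in place of 3-(trifluoromethyl)phenyl gives an at least 1.4-fold higher number from compound 3 to compound 4 (0.17 log units; that floor lies within the scatter). The size of this change is only a floor. In this assay compound 4 alone gives a number, 7400 nM. All other values shown remain limits: the limit of < 5000 nM in this assay, at which 3 of the 4 values shown sit.

The compounds shown do not separate the loss of trifluoromethyl from the entry of dimethylamino. On these data alone, how a morpholine or a carboxylic acid on that phenyl ring would read also remains open.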